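Working notes: compound 1 to compound 4 in the sulfonamide series

The source may hold more compounds than are shown below. What is called first, only, known or untested is meant among the compounds shown, and "the series" means these compounds.

Measured compounds:
compound 1, `C[C@@H](c1ccc(Cl)cc1)N1Cc2cncn2C(CC2(C)COC2)S1(=O)=O`: 35%
compound 2, `CC(C)CC1n2cncc2CN(Cc2ccc(F)cc2)S1(=O)=O`: 39%
compound 3, `CC(C)CC1n2cncc2CN(CC2CC2)S1(=O)=O`: 19%

In an assay on isolated protein for inhibition of Aromatase (Homo sapiens), tested at 1 uM (on this read-out lower numbers stand for less inhibition and higher numbers for more inhibition at the one concentration tested (going by the name of the read-out)), compound 1 stands second highest of the three numbers. Compound 2 lies within the scatter of compound 1; compound 3 lies beyond the scatter, on the lower side. Compound 4, `C[C@@H](c1ccc(Cl)cc1)N1Cc2cncn2C(C[C@H](O)c2ccccc2)S1(=O)=O`, is not yet measured. It differs from compound 1 in one place: hydroxy(phenyl)methyl in place of 3-methyloxetan-3-yl on a saturated chain carbon bound to a saturated ring carbon. Among the measured compounds shown here, the only measured step, a number 20 percentage points lower from compound 2 to compound 3 (beyond the scatter), concerns a different place, a saturated chain carbon bound to the sulfonamide nitrogen; nothing measured bears directly on a change at the saturated chain carbon bound to the saturated ring carbon. No step beyond the scatter is therefore expected in this assay in either direction. Compound 4 is estimated at 38%, between 20% and 56%. The expected step is a number 3 percentage points higher from compound 1 to compound 4 (within the scatter).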

Compound 4, a percentage reported as inhibition, at one concentration (the size of the read-out at that concentration, not a potency): 6%
Beside the measured number, compound 4's estimate is 32 percentage points above it; measured number below the stated range.
By their numbers in this assay, from the lowest: compound 4; then compound 3; then compounds 1 and 2 (each within the scatter of the next).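

In this assay hydroxy(phenyl)methyl in place of 3-methyloxetan-3-yl brings a number 29 percentage points lower from compound 1 to compound 4 (beyond the scatter) on a saturated chain carbon bound to a saturated ring carbon. Among the compounds shown here, this is the first measured step at this place, and it shows that the read-out responds to a change here as well as at the chain carbon bound to the sulfonamide nitrogen. Nothing available accounts for the size or direction of this step.

The change brings in the phenyl ring and the hydroxy group together, so the compounds shown do not separate their contributions. A plain 2-phenylethyl group or a 2-amino-2-phenylethyl group at this place would address that question.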